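Swapping the amide aryl group: from methoxy to fluoromethyl

This account rests on a few compounds, and the source may have more. Where it says the series, first, only, none or still open, it means among the compounds named here.

Of the compounds shown here, two sharing one core have been tested in a functional assay on HCC1937 cells (Homo sapiens) for antiproliferative activity, read by CCK-8 assay, with a stated time of 72 h; on this read-out higher numbers stand for weaker inhibition and lower numbers for stronger inhibition. Compound 1 `O=C(Nc1cccc(-c2oc3cc(-c4ccc(F)cc4)ccc3c(=O)c2O)c1)c1ccc(Cl)cc1` gives 4030 nM, while compound 2 `COc1cccc(C(=O)Nc2cccc(-c3oc4cc(-c5ccc(F)cc5)ccc4c(=O)c3O)c2)c1` gives 18900 nM, the higher of the two numbers. Among the compounds with values here, the only measured step, a 4.7-fold higher number from compound 1 to compound 2 (0.67 log units; beyond the scatter), shows how much the group on the carbonyl carbon matters here.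

Compound 3 `Cc1cc(C(=O)Nc2cccc(-c3oc4cc(-c5ccc(F)cc5)ccc4c(=O)c3O)c2)ccc1F` is made by the change (4-fluoro-3-methylphenyl in place of 3-methoxyphenyl on a carbonyl carbon). This carries the group back toward a halogen-bearing ring, as in compound 1, though with an added methyl and fluorine instead of chlorine. The step from compound 1 to compound 2 is the one that bears on this change, so the number for compound 3 is expected to move down toward compound 1 by about a 2.7-fold lower number from compound 2 to compound 3 (0.43 log units; beyond the scatter) in this assay. Compound 3 is therefore estimated at 7000 nM, with a likely range from 2500 nM to 20000 nM.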

Compound 3, half-maximal inhibitory concentration: 5420 nM
Estimate against measurement, compound 3: 1.3-fold (0.11 log units) above; the range from low to high includes it.
By their numbers in this assay, from the lowest: compounds 1 and 3 (each within the scatter of the next); then compound 2.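

In this assay, the change from 3-methoxyphenyl to 4-fluoro-3-methylphenyl on the carbonyl carbon gives a 3.5-fold lower number from compound 2 to compound 3 (0.54 log units; beyond the scatter) and so reverses most of the loss seen with compound 2. The two halogen-bearing rings cannot be told apart, with a 1.3-fold higher number from compound 1 to compound 3 (0.13 log units; within the scatter) even though they carry different substituents, so among these three compounds only the 3-methoxyphenyl amide stands apart. No measurement shown explains why this ring behaves differently.

The compounds shown do not separate the roles of the fluorine and the methyl in compound 3, and a plain 3-methylphenyl or 4-fluorophenyl group would address that. On these data alone, it also remains open how this assay responds to a ring bearing an amine or a carboxylic acid, or to a longer chain in place of the ring.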